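Swapping a carbamate for methyl on the ring nitrogen

The source may hold more compounds than are shown below. What is called first, only, known or untested is meant among the compounds shown, and "the series" means these compounds.

Compound 1 `Cc1nn(C(=O)C2CC2)c(N)c1-c1ccc(Cl)c(Cl)c1` was tested in an assay on Sf9 cells for inhibition of mitogen-activated protein kinase kinase kinase 14 (Homo sapiens), read by ADP-Glo, with a stated time of 60 min (on this read-out lower numbers stand for stronger inhibition and higher numbers for weaker inhibition), and gave 24300 nM. Compound 2 `Cc1nn(C(=O)OC(C)(C)C)c(N)c1-c1ccc(Cl)c(Cl)c1` differs from it in having tert-butoxy in place of cyclopropyl on a carbonyl carbon. In this assay compound 2 reached only > 100000 nM, which is a limit of the assay rather than a number. That change produced an at least 4.1-fold higher number from compound 1 to compound 2 (0.61 log units; beyond the scatter), so compound 2 stands at the weak end of the two values shown, sitting at the limit of > 100000 nM in this assay, at which 1 of the 2 values shown sits. Compound 3 `Cc1nn(C)c(N)c1-c1ccc(Cl)c(Cl)c1` is not yet measured; it carries methyl in place of tert-butoxycarbonyl on an aromatic nitrogen. For the measured compounds named here, the only measured step concerns what sits on the carbonyl, not the removal of the whole carbonyl-bearing group, so it offers little direct guidance for a change this large. Starting from a limit, the step expected from this change is an at least 3.3-fold lower number from compound 2 to compound 3 (0.52 log units; beyond the scatter). Compound 3 is therefore estimated at 30000 nM, with a range from 5000 nM to 100000 nM.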

Compound 3, half-maximal inhibitory concentration: > 100000 nM
Compound 3: only a limit was reported; the forecaster's own chance of this, stated with the estimate: 40%; at least 3.3-fold (0.52 log units) between middle value and limit.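

In this assay, methyl in place of cyclopropylcarbonyl on the aromatic nitrogen gives an at least 4.1-fold higher number from compound 1 to compound 3 (0.61 log units; beyond the scatter). This goes further than the earlier change on the carbonyl: the whole carbonyl-bearing group is gone, and no readable inhibition remains among the compounds shown, so only the cyclopropylcarbonyl of compound 1 still gives a number. For compound 3, > 100000 nM is a limit of the assay and not a number, and the step between compound 2 and compound 3 cannot be read, as both rest on the same limit: the limit of > 100000 nM in this assay, at which 2 of the 3 values shown sit.

Going by these compounds, how far compound 2 and compound 3 lie beyond that limit stays open. So does whether another group on this nitrogen, such as a longer acyl chain or a chain ending in an amine or a carboxylic acid, would give a lower number than compound 1.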